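This account rests on a few compounds, and the source may have more. Where it says the series, first, only, none or still open, it means among the compounds named here.

Compound 1, `COc1ccc(C(=O)/C=C/c2ccc(F)cc2)c2c1C=CC(C)(C)O2`. In a functional assay on HT-29 cells (Homo sapiens) for antiproliferative activity, read by MTT assay, with a stated time of 24 h (on this read-out lower numbers stand for stronger inhibition and higher numbers for weaker inhibition), compound 1 gives > 10000 nM, which is a limit of this assay and not a number.
Compound 2, `COc1ccc(C(=O)/C=C/c2ccc(Br)cc2)c2c1C=CC(C)(C)O2`. In this assay compound 2 gives > 10000 nM, again a limit of this assay.
Compound 3, `COc1ccc(C(=O)/C=C/c2ccc(N(C)C)cc2)c2c1C=CC(C)(C)O2`. In this assay compound 3 gives 1870 nM.

Among the compounds with values here, compound 3 thus holds the only number among the three values; the other two sit at the limit of > 10000 nM in this assay, at which 2 of the 3 values shown sit. The step from compound 1 to compound 2 is not readable, since a step that the two limits leave unreadable from compound 1 to compound 2. The two steps that end in compound 3 are readable in one direction only: an at least 5.3-fold lower number from compound 1 to compound 3 (0.72 log units; beyond the scatter) and an at least 5.3-fold lower number from compound 2 to compound 3 (0.72 log units; beyond the scatter). Both show that the dimethylamino group is the one substituent shown that brings the number below the limit.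

Compound 4, `COc1ccc(C(=O)/C=C/c2cccc([N+](=O)[O-])c2)c2c1C=CC(C)(C)O2`, has not yet been measured in this assay. It differs from compound 3 in that (3-nitrophenyl in place of 4-(dimethylamino)phenyl on a double-bonded chain carbon bound to a double-bonded chain carbon). Both steps that bear on it, from compound 1 and from compound 2 to compound 3, point the same way: replacing the dimethylamino group by another substituent went with the loss of a readable number. A nitro group is not a halogen, so the match is loose, yet nothing shown favours compound 4. The estimate for compound 4 is therefore a higher number, a 4.3-fold higher number from compound 3 to compound 4 (0.63 log units; beyond the scatter), with a real chance that the assay reports only a limit. The expected value for compound 4 is 8000 nM, in a range from 2000 nM to 30000 nM.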

Compound 4, half-maximal inhibitory concentration: 4260 nM
Beside the measured number, compound 4's estimate is 1.9-fold (0.27 log units) above it; low and high end bracket the measured number.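

Within the data shown here, at this place, on a double-bonded chain carbon bound to a double-bonded chain carbon, 4-(dimethylamino)phenyl is no longer the only group that gives a number in this assay: 3-nitrophenyl gives one too, with a 2.3-fold higher number from compound 3 to compound 4 (0.36 log units; beyond the scatter). Against the two halogen-bearing compounds the same place shows an at least 2.3-fold lower number from compound 2 to compound 4 (0.37 log units; beyond the scatter) and an at least 2.3-fold lower number from compound 1 to compound 4 (0.37 log units; beyond the scatter), so a value under the limit does not depend on the dimethylamino group alone. Compound 1 and compound 2 remain limits of the assay and not numbers: the limit of > 10000 nM in this assay, at which 2 of the 4 values shown sit.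

The compounds shown leave open whether the nitro group itself or its place on the ring matters, since the group and its ring position change together from compound 3 to compound 4. A 4-nitrophenyl or a 3-(dimethylamino)phenyl group would separate the two.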